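The source may hold more compounds than are shown below. What is called first, only, known or untested is meant among the compounds shown, and "the series" means these compounds.

Of the compounds shown here, three sharing one core have been tested so far in a functional assay for inhibition, with Sus scrofa as the target (a lower number here means a stronger inhibitor, a higher number a weaker inhibitor), and only one gives a true number. Compound 1 (`CC1(C)Oc2ccc(C#N)cc2[C@@H](n2ccccc2=O)[C@]1(C)O`) gives > 100000 nM there, which is a limit of the assay and not a number. Compound 2 (`CC1(C)Oc2ccc(C#N)cc2[C@@H](Nn2ccccc2=O)[C@]1(C)O`) gives > 100000 nM there, again a limit. Compound 3 (`CC1(C)Oc2ccc(C#N)cc2[C@@H](Oc2ccc(=O)[nH]n2)[C@]1(C)O`) gives 6 nM in the same test and is the strongest inhibitor of the three. The steps that lead to it are large: an at least 16000-fold lower number from compound 1 to compound 3 (4.22 log units; beyond the scatter) and an at least 16000-fold lower number from compound 2 to compound 3 (4.22 log units; beyond the scatter) both lie beyond the scatter.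

Compound 4 (`CC1(C)Oc2ccc(C#N)cc2[C@@H](Oc2ccc(=O)[nH]n2)[C@@]1(O)COC(=O)c1ccccc1`) keeps the group that compound 3 carries on the saturated ring carbon and differs elsewhere. The change is benzoyloxy in place of hydrogen on a saturated chain carbon bound to a saturated ring carbon and it can also be read as methyl to (benzoyloxy)methyl. Both large steps swap the group on a saturated ring carbon, so neither tests this chain carbon, and neither sets a size for the new step. Starting from compound 3 at 6 nM without a direct guide, a moderate rise in the number is the cautious expectation, with wide margins. The expected change is a 5.0-fold higher number from compound 3 to compound 4 (0.70 log units; beyond the scatter) as an estimate only. For compound 4 the estimated value is 30 nM with an expected range of 4 nM to 300 nM in this assay as the test.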

Compound 4, half-maximal inhibitory concentration: > 100000 nM
Compound 4 ended at the assay's limit; the forecaster's own chance of this, stated with the estimate: 5%; middle value at least 3300-fold (3.52 log units) from the limit.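

Among the compounds shown here, the earlier compounds differed only in the group on a saturated ring carbon, and compound 4 is the first to show that the methyl on the shared core also matters. In this assay, the change from methyl to (benzoyloxy)methyl gives an at least 16000-fold higher number from compound 3 to compound 4 (4.22 log units; beyond the scatter), so a change at this chain carbon alone is enough to take a strong inhibitor to the limit of the test, even with the group on the saturated ring carbon left as it was. The full size of this loss cannot be read because compound 4 gives a limit and not a number: the limit of > 100000 nM in this assay, at which 3 of the 4 values shown sit.

From the compounds shown here alone, it remains open whether a smaller group on this chain carbon, such as the hydroxyl of a hydroxymethyl or the single added carbon of an ethyl, would keep the low number of compound 3, or whether any addition to this methyl loses it. The compounds shown also leave open whether the loss comes from the ring of the benzoyloxy group or from its ester carbonyl, and how an amine or a carboxylic acid would behave at this place.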